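From hydroxy to trifluoromethyl at an assay limit

A few compounds are considered here, and "the series" means these few. Any claim that something is new, unique, unknown or untested is made for them only; others in the source may bear on it.

Of the compounds shown here, three sharing one core have been tested in an ADME assay on BJ cells (Homo sapiens) for cytotoxicity, read by CellTiter-Glo and resazurin assay, with a stated time of 72 h; on this read-out higher numbers stand for an effect only at larger amounts of compound and lower numbers for an effect already at smaller amounts. Compound 1 (`CCOC(=O)CCCCCOc1cccc(CN(C(=O)c2ccc(-c3cccc(Oc4ccccc4)c3)cc2)C(C)C)c1`) gives > 19600 nM, which is a limit. Compound 2 (`CCOC(=O)CCCCCOc1cccc(CN(C(=O)c2ccc(-c3cccc(-c4nnc(C)o4)c3)cc2)C(C)C)c1`) gives > 26000 nM, also a limit. Compound 3 (`CCOC(=O)CCCCCOc1cccc(CN(C(=O)c2ccc(-c3cccc(O)c3)cc2)C(C)C)c1`) gives > 26000 nM, again a limit, so it stands without a number.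

Compound 4 (`CCOC(=O)CCCCCOc1cccc(CN(C(=O)c2ccc(-c3cccc(C(F)(F)F)c3)cc2)C(C)C)c1`), not yet measured, carries trifluoromethyl in place of hydroxy on an aromatic carbon, meta to a large group: trifluoromethyl in place of hydroxy on an aromatic carbon.

The nearest evidence comes from changes at this same place. These are a step that the two limits leave unreadable from compound 1 to compound 3, a step that the two limits leave unreadable from compound 2 to compound 3 and a step that the two limits leave unreadable from compound 1 to compound 2. None of them has a readable size, and all three compounds remain at limits, with compound 2 and compound 3 together at the limit of > 26000 nM in this assay, at which 2 of the 3 values shown sit. On that ground, a number no higher from compound 3 to compound 4 (the limit leaves the size open) is expected to stay within the scatter, with no direction foreseen. Compound 4 is estimated at 26000 nM, with an expected range from 14000 nM to 50000 nM.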

Compound 4, half-maximal effective concentration: < 1.3 nM
Compound 4: only a limit was reported; the forecaster's own chance of this, stated with the estimate: 85%; middle value at least 20000-fold (4.30 log units) from the limit.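

In this assay this position turns out to be far from silent: hydroxy, 5-methyl-1,3,4-oxadiazol-2-yl and phenoxy left only limits, with steps among them that cannot be read, whereas trifluoromethyl gives an at least 20000-fold lower number from compound 3 to compound 4 (4.30 log units; beyond the scatter). The other two groups give the same picture, with an at least 20000-fold lower number from compound 2 to compound 4 (4.30 log units; beyond the scatter) and an at least 15000-fold lower number from compound 1 to compound 4 (4.17 log units; beyond the scatter), so the change is large from each of the three groups it replaces. Compound 4 itself gives a limit and not a number, alone at this end of the values shown: the limit of < 1.3 nM in this assay, at which 1 of the 4 values shown sits.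

Going by these compounds, how far the true value of compound 4 lies past its limit remains open. Also open, on these data alone, is what a methyl, a chlorine or a nitrile would give at this place, and whether trifluoromethyl has the same effect with a carboxylic acid in place of the ethyl ester.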